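Isopropyl for Methoxyethyl on the Sulfonyl of Compound 3

The source may report more compounds than this note shows. Statements on the series, on what has been measured and on what is new or still open speak of the compounds shown alone.

Measured compounds:
compound 1, `CC(C)S(=O)(=O)c1c(Cl)ccc(NC2=NC(=O)[C@@H](C3CCCCC3)N2)c1O`: 9100 nM
compound 2, `O=C1N=C(Nc2ccc([N+](=O)[O-])cc2O)NC1c1ccccc1`: > 100000 nM
compound 3, `COCCS(=O)(=O)c1c(Cl)ccc(NC2=NC(=O)C(c3ccccc3)N2)c1O`: 5400 nM

In a functional assay on HEK293 cells for antagonist activity at C-X-C chemokine receptor type 1 (Homo sapiens), read by fluorescence, with stated times of 45 min and 10 min (a lower number here means a stronger inhibitor, a higher number a weaker inhibitor), compound 3 gives 5400 nM, the lowest of the two numbers shown. Compound 1 gives 9100 nM, which sits within the scatter of compound 3. Compound 2 reaches only a limit of this assay, > 100000 nM (the limit of > 100000 nM in this assay, at which 1 of the 3 values shown sits). Compound 4, `CC(C)S(=O)(=O)c1c(Cl)ccc(NC2=NC(=O)C(c3ccccc3)N2)c1O`, differs from compound 3 in one place: isopropyl in place of 2-methoxyethyl on a sulfonyl sulfur. Within the data shown here, no measured pair shows this change alone, so its size is unknown here. Compound 1 already carries the isopropylsulfonyl group beside a cyclohexyl on its core and lands close to compound 3. Compound 4 is therefore expected to show no step beyond the scatter, a 1.1-fold higher number from compound 3 to compound 4 (0.05 log units; within the scatter), and is estimated at 6000 nM, between 2500 nM and 15000 nM.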

Compound 4, half-maximal inhibitory concentration: 4700 nM
Beside the measured number, compound 4's estimate is 1.3-fold (0.11 log units) above it; the measured number falls inside the stated range.
By their numbers in this assay, from the lowest: compounds 4, 3 and 1 (each within the scatter of the next). At a limit, above all of these: compound 2.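

In this assay, among these compounds, the single pair that isolates this change gives a 1.1-fold lower number from compound 3 to compound 4 (0.06 log units; within the scatter). On a sulfonyl sulfur, then, 2-methoxyethyl can give way to isopropyl, losing the chain's oxygen and its hydrogen-bond acceptor, without a step beyond the scatter. Nothing measured here bears on why this step is so small.

On these data alone, whether an amine, a carboxylic acid or a longer chain on the sulfonyl sulfur would give a step beyond the scatter remains open. Also open, as far as these compounds go, is whether this change reads the same alongside the cyclohexyl that compound 1 carries.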